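The compounds below may be only part of what the source reports. "The series", "measured", "known", "first", "only" and "open" are said of these compounds alone.

Measured compounds:
- compound 1, `CC(C)(C)c1ccc(C(=O)N2CCC3(CC2)C(=O)N(CC(=O)N2CCNCC2)CN3c2ccccc2)cc1`: 22000 nM
- compound 2, `CC(C)(C)c1ccc(C(=O)N2CCC3(CC2)C(=O)N(CC(=O)NCCO)CN3c2ccccc2)cc1`: 1000 nM
- compound 3, `CC(C)(C)c1ccc(C(=O)N2CCC3(CC2)C(=O)N(CC(=O)NCCN)CN3c2ccccc2)cc1`: 7000 nM

All three were tested in an assay on HEK293 cells for displacement of a labelled ligand from NPC1-like intracellular cholesterol transporter 1 (Homo sapiens); on this read-out lower numbers stand for stronger inhibition and higher numbers for weaker inhibition. Compound 3 stands second highest of the three numbers: compound 1 sits a 3.1-fold lower number from compound 1 to compound 3 (0.50 log units; beyond the scatter) away, and compound 2 sits a 7.0-fold higher number from compound 2 to compound 3 (0.85 log units; beyond the scatter) away. Compound 4, `CC(C)(C)c1ccc(C(=O)N2CCC3(CC2)C(=O)N(CC(=O)N2CCCC(C(N)=O)C2)CN3c2ccccc2)cc1`, has not yet been measured; it differs from compound 3 in one place.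

3-carbamoylpiperidin-1-yl in place of (2-aminoethyl)amino on a carbonyl carbon

For the measured compounds named here, three measured steps bear on this change. Going by the values given here, replacing piperazin-1-yl on the carbonyl carbon with an open-chain group gave a 22-fold lower number from compound 1 to compound 2 (1.34 log units; beyond the scatter) and a 3.1-fold lower number from compound 1 to compound 3 (0.50 log units; beyond the scatter), so the one ring-bearing group on that carbonyl carbon went with the weakest number seen. Swapping amino for hydroxy on the chain gave a 7.0-fold higher number from compound 2 to compound 3 (0.85 log units; beyond the scatter). Compound 4 brings back a ring on that carbonyl carbon, as in compound 1, but with a carbamoyl group rather than a ring nitrogen bearing hydrogen, so the measured steps point in no single direction. The expected outcome is therefore a step within or close to the scatter, a 1.2-fold lower number from compound 3 to compound 4 (0.07 log units; within the scatter), with wide uncertainty. Compound 4 is estimated at 6000 nM in this assay, within a range of 1200 nM to 30000 nM.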

Compound 4, half-maximal inhibitory concentration: 16900 nM
For compound 4 the middle estimate is 2.8-fold (0.45 log units) below the measured one; the measured number falls inside the stated range.
By their numbers in this assay, from the lowest: compound 2; then compound 3; then compounds 4 and 1 (each within the scatter of the next).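

In this assay, 3-carbamoylpiperidin-1-yl on the carbonyl carbon gives a weaker result than either open-chain group, by a modest step against (2-aminoethyl)amino (a 2.4-fold higher number from compound 3 to compound 4 (0.38 log units; beyond the scatter)) and a large one against (2-hydroxyethyl)amino (a 17-fold higher number from compound 2 to compound 4 (1.23 log units; beyond the scatter)). Against piperazin-1-yl, the only other ring-bearing group shown, the change leaves the two compounds indistinguishable (a 1.3-fold lower number from compound 1 to compound 4 (0.11 log units; within the scatter)), so across these four compounds the two ring-bearing groups give the higher numbers and the two open chains the lower numbers, with no compound going against this split. No measurement here explains the split.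

For the compounds shown here, with only two ring-bearing groups and two open chains, it remains open whether the ring itself or the groups attached to it set the number. A plain piperidin-1-yl or a morpholin-4-yl on the same carbonyl carbon would help separate those two readings, while a longer chain such as (3-hydroxypropyl)amino would show whether the hydroxy-bearing chain of compound 2 can be extended, and a carboxylic acid in place of the carbamoyl would test that group on the ring.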